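Working notes: phenyl to 2,4-dichlorophenyl

The source may hold more compounds than are shown below. What is called first, only, known or untested is meant among the compounds shown, and "the series" means these compounds.

Values in a functional assay on T47D cells (Homo sapiens) for inhibition, read by sulforhodamine B assay, with a stated time of 48 h; a lower number here means a stronger inhibitor of growth, a higher number a weaker inhibitor of growth:
- compound 1 `O=C(Cc1csc2nc(-c3ccc(Br)cc3)cn12)N/N=C/c1ccccc1`: 37200 nM
- compound 2 `COc1cccc(OC)c1/C=N/NC(=O)Cc1csc2nc(-c3ccc(Br)cc3)cn12`: 40700 nM

Among the measured compounds shown here, compound 1 holds one of only two numbers, and those two lie within the scatter of each other. Compound 3 `O=C(Cc1csc2nc(-c3ccc(Br)cc3)cn12)N/N=C/c1ccc(Cl)cc1Cl` has not yet been measured in this assay. Its difference from compound 1 is 2,4-dichlorophenyl in place of phenyl on a carbon with a double bond to nitrogen. For the measured compounds named here, one measured step bears on this, at the same place, with 2,6-dimethoxyphenyl in place of phenyl: a 1.1-fold higher number from compound 1 to compound 2 (0.04 log units; within the scatter). Going by the values given here, no chlorine-bearing compound has been measured, so this single step is thin support. No step beyond the scatter is expected, and no direction is favoured. The expected step is a 1.1-fold lower number from compound 1 to compound 3 (0.05 log units; within the scatter). For compound 3 the estimated value is 33000 nM, with an expected range of 14000 nM to 65000 nM.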

Compound 3, concentration for 50% growth inhibition: < 100000 nM
Compound 3: no number, only a limit; the forecaster's own chance of this, stated with the estimate: 15%; the middle value lies beyond the limit too.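

In this assay compound 3 gives < 100000 nM, which is a limit and not a number, so its steps from compound 1 and from compound 2 cannot be read. From the compounds shown here alone, whether 2,4-dichlorophenyl in place of phenyl shifts growth inhibition at all, and in which direction, stays open.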